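Swapping Methyl for Chloro on a Shared Amide Core

A few compounds are considered here, and "the series" means these few. Any claim that something is new, unique, unknown or untested is made for them only; others in the source may bear on it.

Two compounds have been measured in a functional assay on A-375 cells (Homo sapiens) for cytotoxicity, read by MTT assay, with a stated time of 72 h; a higher number here means a weaker inhibitor, a lower number a stronger inhibitor:
Compound 1 `O=C(Nc1ccc(Cl)c(C(=O)Nc2ccc(-c3ncc[nH]3)nc2)c1)c1ccc(Cl)c(Cl)c1` gives 9390 nM.
Compound 2 `Cc1ccc(NC(=O)c2ccc(Cl)c(C(F)(F)F)c2)cc1C(=O)Nc1ccc(-c2ncc[nH]2)nc1` gives 14400 nM.

Compound 2 has the higher of these two numbers, but its gap to compound 1 lies within the scatter, so the two cannot be told apart. Compound 3 `O=C(Nc1ccc(Cl)c(C(=O)Nc2ccc(-c3ncc[nH]3)nc2)c1)c1ccc(Cl)c(C(F)(F)F)c1` carries chloro in place of methyl on an aromatic carbon. Going by the values given here, no step between measured compounds isolates this swap, and compound 1, which also bears chloro, sits within the scatter of compound 2; no shift beyond the scatter is therefore expected, and a 1.3-fold lower number from compound 2 to compound 3 (0.12 log units; within the scatter) is the estimated step. Compound 3 is expected to give 11000 nM, between 4500 nM and 27000 nM.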

Compound 3, half-maximal inhibitory concentration: 4260 nM
Compound 3: middle estimate off by 2.6-fold (0.41 log units), on the high side; the measured number lies below the stated range.
By their numbers in this assay, from the lowest: compound 3; then compounds 1 and 2 (each within the scatter of the next).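

In this assay, chloro in place of methyl on this aromatic carbon, ortho to a large group and para to a large group, gives a 3.4-fold lower number from compound 2 to compound 3 (0.53 log units; beyond the scatter), a modest gain in strength. Trifluoromethyl in place of chloro on an aromatic carbon gives a 2.2-fold lower number from compound 1 to compound 3 (0.34 log units; beyond the scatter), so this second single change also matters, and compound 3 is the strongest of the three. No measured evidence here accounts for either step.

As far as these compounds go, how an amine or a methoxy group would compare with chloro at this position remains open.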